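A few compounds are considered here, and "the series" means these few. Any claim that something is new, unique, unknown or untested is made for them only; others in the source may bear on it.

In a functional assay on NCI-H522 cells (Homo sapiens) for inhibition, read by sulforhodamine B assay, with a stated time of 48 h (a lower number here means that less compound is tolerated, a higher number that more compound is tolerated), compound 2, `COc1cc(-c2nn(-c3cccc(NC(=O)Nc4ccc(Cl)c(C(F)(F)F)c4)c3)cc2-c2ccncc2)ccc1Cl`, gives only a limit of > 32500 nM rather than a measured number. Going by these compounds, compound 2 therefore stands at the limit of > 32500 nM in this assay, at which 2 of the 2 values shown sit, and its true value is unknown beyond that bound. Compound 1, `O=C(Nc1cccc(-n2cc(-c3ccncc3)c(-c3ccc(Cl)c(O)c3)n2)c1)Nc1cccc(C(F)(F)F)c1`, likewise reaches only a limit of > 32500 nM in this assay. Compound 3, `O=C(Nc1cccc(-n2cc(-c3ccncc3)c(-c3ccc(Cl)c(O)c3)n2)c1)Nc1ccc(Cl)c(C(F)(F)F)c1`, differs from compound 2 by hydrogen in place of methyl on an oxygen on an aromatic ring, which turns the methoxy group into a hydroxy group. Compound 1 already carries that hydroxy group on the same ring, and its result is a limit as well. On these numbers the expected step is a step that the limit leaves unreadable from compound 2 to compound 3, nothing beyond the usual scatter. For compound 3 the estimated value in this assay is 40000 nM, with a range from 15000 nM to 100000 nM, most likely reported once more only as a limit.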

Compound 3, concentration lethal to 50% of the cells: 24500 nM
Beside the measured number, compound 3's estimate is 1.6-fold (0.21 log units) above it; the measured number falls inside the stated range.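

Within the data shown here, compound 3 is the only one of the three compounds with a measured number rather than a limit in this assay: the limit of > 32500 nM in this assay, at which 2 of the 3 values shown sit. This gives the first readable steps, though only as floors: changing methoxy to hydroxy on the aromatic ring gives an at least 1.3-fold lower number from compound 2 to compound 3 (0.12 log units; that floor lies within the scatter), and placing chloro instead of hydrogen on an aromatic carbon gives an at least 1.3-fold lower number from compound 1 to compound 3 (0.12 log units; that floor lies within the scatter). Both floors lie within the scatter, so neither change can yet be said to shift the tolerated concentration.

Going by these compounds, how far compound 1 and compound 2 lie past their limits stays open, and with it the true size of both steps. Also open, on these data alone, is whether an amine or an ethoxy group in place of the hydroxy group of compound 3 would move the number.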